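Alkylamino variation at the core nitrogen: toward butyl

The source may hold more compounds than are shown below. What is called first, only, known or untested is meant among the compounds shown, and "the series" means these compounds.

Among the measured compounds shown here, compound 2 `O=C(Nc1ccc(F)cc1)c1ccc(CNc2nc(NC3CC3)nc3ccccc23)cc1` gives 2700 nM in a functional assay on HCT-116 cells (Homo sapiens) for inhibition, read by luminescence and resazurin assay, with a stated time of 3 days; a lower number here means a stronger inhibitor, a higher number a weaker inhibitor; the only other number, from compound 1 `CNc1nc(NCc2ccc(C(=O)Nc3ccc(F)cc3)cc2)c2ccccc2n1` at 2900 nM in this assay, lies within the scatter of it. For the measured compounds named here, the single measured step, a 1.1-fold lower number from compound 1 to compound 2 (0.03 log units; within the scatter), concerns the same nitrogen. Compound 3 `CCCCNc1nc(NCc2ccc(C(=O)Nc3ccc(F)cc3)cc2)c2ccccc2n1` carries butyl in place of cyclopropyl on a nitrogen on an aromatic ring, the same difference cut one bond further out reading cyclopropylamino to butylamino. With a 1.1-fold lower number from compound 1 to compound 2 (0.03 log units; within the scatter) staying within the scatter, no step beyond the scatter is expected for compound 3, giving a 1.0-fold lower number from compound 2 to compound 3 (0.02 log units; within the scatter). Compound 3 is thus estimated at 2600 nM, range 1000 nM to 7000 nM.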

Compound 3, half-maximal inhibitory concentration: 1400 nM
For compound 3 the middle estimate is 1.9-fold (0.27 log units) above the measured one; low and high end bracket the measured number.
By their numbers in this assay, from the lowest: compounds 3, 2 and 1 (each within the scatter of the next, the first and the last beyond it).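

Butyl on this nitrogen gives the only step beyond the scatter so far in this assay (a 2.1-fold lower number from compound 1 to compound 3 (0.32 log units; beyond the scatter)), although that step is modest. Against cyclopropyl, the same chain stays within the scatter (a 1.9-fold lower number from compound 2 to compound 3 (0.29 log units; within the scatter)), so butyl is separated from methyl but not from cyclopropyl. Nothing available explains this difference.

As far as these compounds go, how a longer chain such as hexyl would read on this nitrogen remains open. So does the reading of a butyl chain ending in a dimethylamino group or a carboxylic acid.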